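A few compounds are considered here, and "the series" means these few. Any claim that something is new, unique, unknown or untested is made for them only; others in the source may bear on it.

- Compound 1 `COc1ccc(C(=O)c2ccc3c(c2)C=CC(C)(C)O3)c(NC(=O)CBr)c1` gives 2880 nM
- Compound 2 `COc1ccc(C(=O)c2ccc(OC)c3c2OC(C)(C)C=C3)c(NC(=O)CO)c1` gives 320 nM
- Compound 3 `CNCC(=O)Nc1cc(OC)ccc1C(=O)c1ccc(OC)c2c1C=CC(C)(C)O2` gives 3040 nM

All three values come from a functional assay on MCF7 cells (Homo sapiens) for antiproliferative activity, read by MTT assay, with a stated time of 48 h (a higher number here means a weaker inhibitor, a lower number a stronger inhibitor), and compound 2 is the most potent of the three at 320 nM with its gaps to compound 1 and compound 3 both beyond the scatter.

Compound 4 `COc1ccc(C(=O)c2ccc(OC)c3c2OC(C)(C)C=C3)c(NC(=O)CN(C)C)c1` has not yet been measured. It differs from compound 2 in one place, with dimethylamino in place of hydroxy on a saturated chain carbon bound to a carbonyl carbon and everything else unchanged.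

Among the measured compounds shown here, no two measured compounds differ in only one place, so the data show no direct precedent for this swap. The closest hint is compound 3, which also carries an amine rather than the hydroxy and gives 3040 nM in this assay but it also differs from compound 2 elsewhere, making it only a loose guide.

The expected step of a 3.4-fold higher number from compound 2 to compound 4 (0.54 log units; beyond the scatter) is towards a higher number and a weaker inhibitor, probably beyond the scatter, although a much smaller shift remains possible. For compound 4 the estimated value is 1100 nM with an expected range from 300 nM to 4000 nM in this measurement.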

Compound 4, half-maximal inhibitory concentration: 2680 nM
Beside the measured number, compound 4's estimate is 2.4-fold (0.39 log units) below it; measured number inside the range.
By their numbers in this assay, from the lowest: compound 2; then compounds 4, 1 and 3 (each within the scatter of the next).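

In this assay, among the compounds shown here, putting dimethylamino in place of hydroxy on a saturated chain carbon bound to a carbonyl carbon gives an 8.4-fold higher number from compound 2 to compound 4 (0.92 log units; beyond the scatter) and so provides the first direct reading of a single change at this position. Potency at this place therefore depends on what the chain carries, and the hydroxy of compound 2 cannot be exchanged for dimethylamino without a clear loss. The change alters several things at once, with 1 heavy atom giving way to 3, a nitrogen replacing an oxygen and the count of hydrogen-bond donors falling from 1 to 0, and nothing measured here explains the step or singles out which of these differences matters.

The compounds shown leave open how methoxy or a plain amino group at this place would compare with the hydroxy of compound 2, and so whether the loss tracks the missing hydrogen-bond donor, the larger group or the nitrogen. They also leave open what a longer chain ending in hydroxy or a carboxylic acid would do to the activity of compound 2.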